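The source may report more compounds than this note shows. Statements on the series, on what has been measured and on what is new or still open speak of the compounds shown alone.

Of the compounds shown here, three sharing one core have been measured in an assay on isolated protein for displacement of a labelled ligand from prostaglandin E2 receptor EP3 subtype (Homo sapiens); on this read-out higher numbers stand for weaker inhibition and lower numbers for stronger inhibition. Compound 1 `Cc1cn(Cc2ccc(Cl)cc2Cl)c2c(-c3nnc(NS(=O)(=O)c4cc(Cl)c(Cl)s4)o3)cc(F)cc12` gives 10 nM. Compound 2 `Cc1cn(Cc2ccc(Cl)cc2Cl)c2c(-c3nnc(NS(=O)(=O)c4cc(F)c(F)cc4F)o3)cc(F)cc12` gives 2 nM. Compound 3 `Cc1cn(Cc2ccc(Cl)cc2Cl)c2c(-c3nnc(NS(=O)(=O)c4ccc(Cl)c(Cl)c4)o3)cc(F)cc12` gives 4 nM, which places it second highest of the three numbers, with compound 2 as its nearest neighbour and compound 1 as its furthest.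

Compound 4 `Cc1cn(Cc2ccc(Cl)cc2Cl)c2c(-c3nnc(NS(=O)(=O)c4ccc(F)c(F)c4)o3)cc(F)cc12` has not yet been measured. It differs from compound 3 in one place: 3,4-difluorophenyl in place of 3,4-dichlorophenyl on a sulfonyl sulfur.

Which measured steps speak to this exchange of two chlorines for two fluorines on the phenyl ring? The step of a 2.5-fold lower number from compound 1 to compound 3 (0.40 log units; beyond the scatter) and the step of a 5.0-fold lower number from compound 1 to compound 2 (0.70 log units; beyond the scatter) both replace the thiophene ring, so they touch the ring rather than its halogens. The most informative comparison is a 2.0-fold higher number from compound 2 to compound 3 (0.30 log units; within the scatter), where a fluorinated phenyl and a chlorinated phenyl give numbers that cannot be told apart. Moving from chlorines to fluorines on the same ring positions is therefore expected to produce a step of about no change at the digits printed from compound 3 to compound 4 (within the scatter), that is, nothing clearly beyond the scatter, with a slight lean toward a lower number if anything.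

On that basis compound 4 is estimated to give 4 nM in this assay, within a range from 1.5 nM to 12 nM.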

Compound 4, half-maximal inhibitory concentration: 20 nM
Estimate against measurement, compound 4: 5.0-fold (0.70 log units) below, and the stated range ends below it.
By their numbers in this assay, from the lowest: compounds 2 and 3 (each within the scatter of the next); then compounds 1 and 4 (each within the scatter of the next).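

In this assay, among these compounds, the identity of the halogen matters on this phenyl ring attached to the sulfonyl sulfur: with the ring positions kept the same, 3,4-difluorophenyl in place of 3,4-dichlorophenyl gives a step beyond the scatter (a 5.0-fold higher number from compound 3 to compound 4 (0.70 log units; beyond the scatter)), whereas the earlier compounds only compared rings with different substitution patterns or a thiophene with a phenyl. A single substituent also counts, since hydrogen in place of one fluoro on an aromatic carbon, turning 2,4,5-trifluorophenyl into 3,4-difluorophenyl, gives the largest step seen so far (a 10-fold higher number from compound 2 to compound 4 (1.00 log units; beyond the scatter)), so fluorinated phenyl rings cannot be treated as interchangeable. By contrast, 3,4-difluorophenyl and 4,5-dichlorothiophen-2-yl cannot be told apart (a 2.0-fold higher number from compound 1 to compound 4 (0.30 log units; within the scatter)), which shows that a change of ring here need not move the number beyond the scatter.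

Nothing among the data shown accounts for why these halogen changes have such different effects. As far as these compounds go, it also remains open how a phenyl ring carrying a methoxy group or a nitrile in place of the halogens would read in this assay.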